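A few compounds are considered here, and "the series" means these few. Any claim that something is new, unique, unknown or untested is made for them only; others in the source may bear on it.

Measured compounds in an assay for positive allosteric modulation of metabotropic glutamate receptor 2 (Rattus norvegicus); a lower number here means that less compound is needed, a higher number that more compound is needed for the effect:
- compound 1, `Cc1ncc(OCCCCOc2ccc(C(=O)CC(C)(C)C)c(O)c2C)cc1C(=O)O`: 28 nM
- compound 2, `COc1cc(OCCCCOc2ccc(C(=O)CC(C)(C)C)c(O)c2C)cc(C(=O)O)c1`: 102 nM
- compound 3, `Cc1c(OCCCCOc2ccc(C(=O)O)c(F)c2)ccc(C(=O)CC(C)(C)C)c1O`: 80 nM

Compound 3 stands second highest of the three numbers; compound 2 is nearest, within the scatter, while compound 1 is the furthest, with a 2.9-fold higher number from compound 1 to compound 3 (0.46 log units; beyond the scatter) a modest step beyond the scatter. Compound 4, `Cc1c(OCCCCOc2ccc(F)c(C(N)=O)c2)ccc(C(=O)CC(C)(C)C)c1O`, is not yet measured. It differs from compound 3 by 3-carbamoyl-4-fluorophenyl in place of 4-carboxy-3-fluorophenyl on an oxygen on a saturated carbon. For the measured compounds named here, the only measured step on this oxygen, from compound 1 to compound 3, swapped the whole aryl group and was modest; no measured step exchanges a carboxylic acid for a carboxamide on this ring, so the direction is uncertain. For compound 4 a small step, a 1.9-fold higher number from compound 3 to compound 4 (0.27 log units; within the scatter), is expected in this assay, giving an estimated 150 nM with a range from 50 nM to 500 nM.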

Compound 4, half-maximal effective concentration: > 10000 nM
Compound 4: a limit, no number; the forecaster's own chance of this, stated with the estimate: 5%; at least 66-fold (1.82 log units) between middle value and limit.
By their numbers in this assay, from the lowest: compound 1; then compounds 3 and 2 (each within the scatter of the next). At a limit, above all of these: compound 4.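

In this assay compound 4 gives only a limit of the assay, not a number: the limit of > 10000 nM in this assay, at which 1 of the 4 values shown sits. Exchanging one carboxylic acid-bearing aryl group for another on this oxygen was a modest step, whereas the carboxamide-bearing group brings an at least 120-fold higher number from compound 3 to compound 4 (2.09 log units; beyond the scatter). The gap is as wide against the best-placed acid, with an at least 350-fold higher number from compound 1 to compound 4 (2.55 log units; beyond the scatter), so on this oxygen the aryl group's substituents can decide whether any effect is seen at all.

The change moves both the carbamoyl group and the fluorine, so the compounds shown do not separate the two. Going by these compounds, how a tetrazole in place of the carboxylic acid would read also stays open.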